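The source may report more compounds than this note shows. Statements on the series, on what has been measured and on what is new or still open speak of the compounds shown alone.

Within the data shown here, in a physicochemical assay for solubility, with a stated time of 4 h, at pH 2.0 (a lower number here means a less soluble compound, a higher number a more soluble compound), compound 3 `Cc1cc(/C=C/C#N)cc(C)c1Oc1cc(Nc2ccc(C#N)cc2)c(N)cc1C(F)(F)F` gives 0.42 ug/mL as the lowest of the three numbers so far. Compound 1 `Cc1cc(/C=C/C#N)cc(C)c1Oc1cc(Nc2ccc(C#N)cc2)c(N)cc1C(N)=O` gives 2.09 ug/mL and stands nearest to it, while compound 2 `Cc1cc(CCC#N)cc(C)c1Oc1cc(Nc2ccc(C#N)cc2)c(N)cc1CO` gives 89.8 ug/mL and stands furthest. Compound 4 `Cc1cc(/C=C/C#N)cc(C)c1Oc1cc(Nc2ccc(C#N)cc2)c(N)cc1CO` keeps the unsaturated nitrile chain of compound 3 and carries hydroxymethyl in place of trifluoromethyl on an aromatic carbon para to a (4-cyanophenyl)amino group. Among the measured compounds shown here, one measured step touches this carbon: carbamoyl gives way to trifluoromethyl in a 5.0-fold lower number from compound 1 to compound 3 (0.70 log units; beyond the scatter) and that step is modest. It does not involve hydroxymethyl and sets only a scale. The other guide is compound 2 at 89.8 ug/mL which already carries hydroxymethyl but has a saturated nitrile chain where compound 4 has the unsaturated one. For the measured compounds named here, how much of the gap between compound 2 and compound 3 belongs to that chain is not known, and no measured pair isolates it. A rise in this assay is expected, larger than the modest step and well short of the full gap to compound 2. The expected step is a 24-fold higher number from compound 3 to compound 4 (1.38 log units; beyond the scatter) and lies beyond the scatter. Compound 4 is estimated at 10 ug/mL with an expected range of 2 ug/mL to 50 ug/mL.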

Compound 4, solubility: 20.9 ug/mL
Compound 4: the middle estimate sits 2.1-fold (0.32 log units) below what was measured; measured number inside the range.
By their numbers in this assay, from the lowest: compound 3; then compound 1; then compound 4; then compound 2.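

In this assay, hydroxymethyl in place of trifluoromethyl on the aromatic carbon para to a (4-cyanophenyl)amino group gives a 50-fold higher number from compound 3 to compound 4 (1.70 log units; beyond the scatter) and is the largest step yet seen at this carbon. Hydroxymethyl in place of carbamoyl gives a 10-fold higher number from compound 1 to compound 4 (1.00 log units; beyond the scatter) on the same unsaturated nitrile chain, so among the three groups at this carbon, the numbers rise from trifluoromethyl through carbamoyl to hydroxymethyl, with every step beyond the scatter. The chain can now be read on its own, as 2-cyanoethenyl in place of 2-cyanoethyl gives a 4.3-fold lower number from compound 2 to compound 4 (0.63 log units; beyond the scatter) with hydroxymethyl held fixed, which shows that both places contribute to the gap between compound 2 and compound 3, with the larger step at the aromatic carbon.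

From the compounds shown here alone, whether an aminomethyl group or a carboxylic acid at this carbon would carry the number beyond hydroxymethyl stays open, as does the size of the trifluoromethyl to hydroxymethyl step on the 2-cyanoethyl chain. Nothing in hand bears on what lies behind these numbers.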